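Swapping a methoxyphenyl for a difluorophenyl on the ketone

A few compounds are considered here, and "the series" means these few. Any claim that something is new, unique, unknown or untested is made for them only; others in the source may bear on it.

Measured compounds:
Compound 1 `COc1cc(-c2cc(/C=C/C(=O)c3ccc(Cl)c(Cl)c3)[nH]n2)cc(OC)c1OC`: 106%
Compound 2 `COc1ccc(C(=O)/C=C/c2cc(-c3cc(OC)c(OC)c(OC)c3)n[nH]2)cc1OC`: 92%
Compound 3 `COc1ccc(C(=O)/C=C/c2cc(-c3cc(OC)c(OC)c(OC)c3)n[nH]2)cc1`: 102%

In a functional assay on K562 cells (Homo sapiens) for cytotoxicity, read by sulforhodamine B assay, with a stated time of 48 h, tested at 0.1 uM (a higher number here means a weaker effect of the compound at the concentration tested, a lower number a stronger effect), compound 3 gives 102%. It is separated from compound 1 by a number 4 percentage points lower from compound 1 to compound 3 (within the scatter) and from compound 2 by a number 10 percentage points higher from compound 2 to compound 3 (within the scatter), so its number cannot be told apart from either neighbour. Among the compounds with values here, the only step beyond the scatter is a number 14 percentage points lower from compound 1 to compound 2 (beyond the scatter).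

Compound 4 `COc1cc(-c2cc(/C=C/C(=O)c3ccc(F)c(F)c3)[nH]n2)cc(OC)c1OC` is the next structure. The change from compound 3 is 3,4-difluorophenyl in place of 4-methoxyphenyl on a carbonyl carbon. The step that bears on it most directly is a number 4 percentage points lower from compound 1 to compound 3 (within the scatter), which also exchanged a halogenated ring for the methoxy-bearing ring on the carbonyl carbon and stayed within the scatter. Compound 4 carries a halogenated ring again, so the expected step of a number 2 percentage points higher from compound 3 to compound 4 (within the scatter) is none beyond the scatter, in this assay. Compound 4 is therefore estimated at 104%, with a range from 94% to 114%.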

Compound 4, a percentage reported as activity, at one concentration (the size of the read-out at that concentration, not a potency): 109%
Estimate against measurement, compound 4: 5 percentage points below; the measured number falls inside the stated range.
By their numbers in this assay, from the lowest: compounds 2, 3, 1 and 4 (each within the scatter of the next, the first and the last beyond it).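

In this assay, swapping chlorine for fluorine on the ring at the carbonyl carbon gives no readable difference, with a number 3 percentage points higher from compound 1 to compound 4 (within the scatter). Measured against the 3,4-dimethoxyphenyl ring, the 3,4-difluorophenyl ring gives a second step beyond the scatter, a number 17 percentage points higher from compound 2 to compound 4 (beyond the scatter), so both dihalogenated rings now stand apart from compound 2, while compound 3 goes against a clean split between halogen and methoxy, with a number 7 percentage points higher from compound 3 to compound 4 (within the scatter). Nothing measured here explains these differences.

The compounds shown leave open whether a different group on this ring, such as an amine or a carboxylic acid, would move the number, and whether a ring bearing a single fluorine would match the 3,4-difluorophenyl ring. As far as these compounds go, all four were read at one concentration, so how they compare at higher concentrations remains unknown.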